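The source may report more compounds than this note shows. Statements on the series, on what has been measured and on what is new or still open speak of the compounds shown alone.

Notes on the series. Compound 2 `N#CN/C(=N\CCCCNC(=O)c1ccccc1)NCCCOc1cccc(CN2CCCCC2)c1` has been measured in a functional assay on cardiac atrium for antagonist activity at histamine H2 receptor (Cavia porcellus); a lower number here means a less potent compound, a higher number a more potent compound, by a factor of ten per unit of this negative logarithm; compound 2 gives 6.81. The only comparator so far is compound 1 `N#CN/C(=N\CCNC(=O)c1ccncc1)NCCCOc1cccc(CN2CCCCC2)c1`, which in this assay gives 6.89. The two numbers lie within the scatter of each other, so no order between compound 1 and compound 2 can be claimed. Within the data shown here, the one measured step, a number 0.08 log units lower from compound 1 to compound 2 (within the scatter), replaces the ((pyridin-4-yl)carbonyl)amino terminus with 2-benzamidoethyl and stays within the scatter.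

Compound 3 `N#CN/C(=N\CCCCCNC(=O)c1ccccc1)NCCCOc1cccc(CN2CCCCC2)c1` is the next member and has not yet been measured in this assay. Its difference from compound 2 is benzamidomethyl in place of benzamido on a saturated chain carbon, four bonds along the chain from a double-bonded nitrogen. The chain toward the benzamido terminus grows by one saturated carbon; the terminal amide and the rest of the shared core remain as in compound 2. Among the measured compounds shown here, no measured step isolates chain length by itself; the only step that bears on it, a number 0.08 log units lower from compound 1 to compound 2 (within the scatter), combined a longer chain with a change of the terminal ring and did not move beyond the scatter. On that basis the step of a number 0.06 log units lower from compound 2 to compound 3 (within the scatter) is expected to stay within the scatter, with no clear direction. Compound 3 is therefore expected to give about 6.75, with a range from 6.25 to 7.25.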

Compound 3, negative logarithm of the antagonist equilibrium constant: 6.58
Compound 3: middle estimate off by 0.17 log units, on the high side; measured number inside the range.
By their numbers in this assay, from the lowest: compounds 3, 2 and 1 (each within the scatter of the next, the first and the last beyond it).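

In this assay, among these compounds, lengthening the benzamido chain by one saturated carbon gives a number 0.23 log units lower from compound 2 to compound 3 (within the scatter) and is the first measured step to change chain length alone, so this single change does not separate the two compounds. Among the compounds shown here, the wider comparison, with 3-benzamidopropyl in place of ((pyridin-4-yl)carbonyl)amino, gives a number 0.31 log units lower from compound 1 to compound 3 (beyond the scatter) and is the first step to pass the scatter, though only modestly; it combines a longer chain with a different terminal ring, so neither change can be credited on its own. Nothing measured beyond these potency numbers bears on the result.

The compounds shown leave open whether a chain longer than that of compound 3 would move the number beyond the scatter from compound 2, and how much of the modest step belongs to the terminal ring, which a ((pyridin-4-yl)carbonyl)amino terminus on the chain of compound 3 would separate from chain length. They also leave open how a primary amine or a carboxylic acid in place of the benzamido terminus would read in this assay on the same shared core.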